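A few compounds are considered here, and "the series" means these few. Any claim that something is new, unique, unknown or untested is made for them only; others in the source may bear on it.

Measured so far in a functional assay on HepG2 cells (Homo sapiens) for inhibition, read by MTT assay, with a stated time of 24 h; a lower number here means a stronger inhibitor, a higher number a weaker inhibitor
- compound 1 `CC1(C)[C@H]2CC[C@]1(C)N(Cc1cn(-c3ccc(F)cc3)nn1)C(=O)C2` gives 90 nM
- compound 2 `CC1(C)[C@H]2CC[C@]1(C)N(Cc1cn(-c3ccc(O)cc3)nn1)C(=O)C2` gives 80 nM
- compound 3 `CC1(C)[C@H]2CC[C@]1(C)N(Cc1cn(-c3cccc(O)c3)nn1)C(=O)C2` gives 70 nM

Compound 3 cannot be told apart from the other two, since both a 1.1-fold lower number from compound 2 to compound 3 (0.06 log units; within the scatter) and a 1.3-fold lower number from compound 1 to compound 3 (0.11 log units; within the scatter) lie within the scatter.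

The step to compound 4 `Cc1cccc(-n2cc(CN3C(=O)C[C@@H]4CC[C@@]3(C)C4(C)C)nn2)c1` puts methyl in place of hydroxy on an aromatic carbon, a change from 3-hydroxyphenyl to 3-methylphenyl methyl in place of hydroxy on an aromatic carbon with the rest of the structure kept.

For the measured compounds named here, no measured step introduces methyl, so the evidence is indirect. The nearest guide is the exchange of hydroxy for another group. Going from hydroxy back to fluoro is the reverse of the measured change (a 1.1-fold lower number from compound 1 to compound 2 (0.05 log units; within the scatter)), and that step lies within the scatter. Compound 1 has no hydroxy and still gives 90 nM in this assay, within the scatter of both hydroxy compounds. Going by the values given here, all three measured changes on this aryl group are small, and no compound here goes against that.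

No step beyond the scatter is therefore expected in this assay, and no direction can be favoured. The expected step is a 1.1-fold higher number from compound 3 to compound 4 (0.06 log units; within the scatter) and remains an estimate. Compound 4 is estimated at 80 nM with an expected range from 40 nM to 170 nM in this assay.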

Compound 4, half-maximal inhibitory concentration: 300 nM
The estimate for compound 4 lay 3.8-fold (0.57 log units) below the measured number, and the stated range ends below it.
By their numbers in this assay, from the lowest: compounds 3, 2 and 1 (each within the scatter of the next); then compound 4.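

In this assay, for the compounds shown here, the position on the aromatic carbon meta to a large group proves sensitive to at least one exchange: methyl in place of hydroxy gives a 4.3-fold higher number from compound 3 to compound 4 (0.63 log units; beyond the scatter) and is the first step in this set to pass beyond the scatter. The 3-methylphenyl group also separates from both other aryl groups, with a 3.8-fold higher number from compound 2 to compound 4 (0.57 log units; beyond the scatter) and a 3.3-fold higher number from compound 1 to compound 4 (0.52 log units; beyond the scatter) as the two further steps, so the earlier flat picture across the aryl variants holds only for compounds 1, 2 and 3. Loss of hydroxy alone does not fit as a rule, since compound 1 carries no hydroxy and stays within the scatter of compounds 2 and 3, and nothing at hand explains the step.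

Open, on these data alone, is whether the step belongs to methyl as such or extends to other groups in the same place on the ring, such as methoxy, an amine or a carboxylic acid. Also open, as far as these compounds go, is whether a longer chain such as ethyl would go further in the same direction as methyl or behave differently.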